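Halogen swap on the arylidene of an oxindole series

The compounds below may be only part of what the source reports. "The series", "measured", "known", "first", "only" and "open" are said of these compounds alone.

Measured compounds:
- compound 1 `O=C1/C(=C\c2cccc(Oc3ccccc3)c2)c2ccccc2N1c1c(Cl)cccc1Cl`, in a functional assay on L132 cells (Homo sapiens) for cytotoxicity, read by MTT assay, with a stated time of 72 h (a higher number here means that more compound is needed for the effect, a lower number that less compound is needed), compound 1 gives 24 ug/mL
- compound 2 `O=C1/C(=C\c2cccc(Br)c2)c2ccccc2N1c1c(Cl)cccc1Cl`, in this assay compound 2 gives 19 ug/mL
- compound 3 `Cc1ccc2nc(Cl)c(/C=C3\C(=O)N(c4c(Cl)cccc4Cl)c4ccccc43)cc2c1`, in this assay compound 3 gives "not determined" (no result reported)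

Compound 2 stands as the lowest of the two numbers available, with compound 1 nearest; the step of a 1.3-fold lower number from compound 1 to compound 2 (0.10 log units; within the scatter) is within the scatter, so the two cannot be ordered.

Compound 4 `O=C1/C(=C\c2ccc(Cl)cc2)c2ccccc2N1c1c(Cl)cccc1Cl` is the next member to be tested. Relative to compound 2 the change is:
4-chlorophenyl in place of 3-bromophenyl on a double-bonded chain carbon bound to a double-bonded ring carbon

Among the measured compounds shown here, no measured step concerns this exact exchange. For the measured compounds named here, the only step in hand, a 1.3-fold lower number from compound 1 to compound 2 (0.10 log units; within the scatter), shows that altering the substituent on this aryl ring left the number within the scatter, and compound 3 contributes no number. On that basis the expected step of a 1.1-fold higher number from compound 2 to compound 4 (0.02 log units; within the scatter) is small, with no direction favoured beyond the scatter. For compound 4 in this assay the estimate is 20 ug/mL, expected to lie between 10 ug/mL and 40 ug/mL.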

Compound 4, concentration for half-maximal effect: 9 ug/mL
The estimate for compound 4 lay 2.2-fold (0.35 log units) above the measured number; measured number below the stated range.
By their numbers in this assay, from the lowest: compound 4; then compounds 2 and 1 (each within the scatter of the next).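

In this assay, the exchange of 3-bromophenyl for 4-chlorophenyl gives a 2.1-fold lower number from compound 2 to compound 4 (0.32 log units; beyond the scatter) and is thus a modest step, whereas a 1.3-fold lower number from compound 1 to compound 2 (0.10 log units; within the scatter) left its pair unseparated. The number at this position therefore does respond to the aryl group carried on the double-bonded chain carbon, even though the entering and leaving groups match in heavy-atom count and each has no hydrogen-bond donors or acceptors. The halogen and its place on the ring change together in this one step, so their contributions cannot be separated, and no measurement at hand gives a cause for the shift.

Still open, as far as these compounds go, is whether the number follows the identity of the halogen or its place on the ring. Also open, from the compounds shown here alone, is how an aryl ring bearing an amine or a carboxylic acid would behave here.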